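This account rests on a few compounds, and the source may have more. Where it says the series, first, only, none or still open, it means among the compounds named here.

Measured so far:
- compound 1, `COc1ccccc1/C=C/C(=O)/C=C/c1ccc(OCc2cn(CCOc3cc(=O)oc4ccccc34)nn2)c(OC)c1` — in a functional assay on HCT-116 cells (Homo sapiens) for cytotoxicity, read by sulforhodamine B assay, with a stated time of 48 h (on this read-out higher numbers stand for weaker inhibition and lower numbers for stronger inhibition), compound 1 gives 9490 nM
- compound 2, `COc1cc(/C=C/C(=O)/C=C/c2cc(OC)c(OC)c(OC)c2)ccc1OCc1cn(CCOc2cc(=O)oc3ccccc23)nn1` — compound 2 gives 2210 nM
- compound 3, `COc1cc(/C=C/C(=O)/C=C/c2cc(OC)c(OC)c(OC)c2)ccc1OCc1cn(CCCOc2cc(=O)oc3ccccc23)nn1` — compound 3 gives 8650 nM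

Compound 2 has the lowest number of the three, and its gap to compound 3 and to compound 1 lies beyond the scatter in both cases, so it is the strongest inhibitor among the measured set.

Compound 4, `COc1ccc(/C=C/C(=O)/C=C/c2ccc(OCc3cn(CCOc4cc(=O)oc5ccccc45)nn3)c(OC)c2)cc1OC`, differs from compound 2 in one place: hydrogen in place of methoxy on an aromatic carbon.

Among the compounds with values here, one measured step bears on this change. Going a 4.3-fold lower number from compound 1 to compound 2 (0.63 log units; beyond the scatter), the number fell when the aryl group on that chain carbon went from 2-methoxyphenyl to 3,4,5-trimethoxyphenyl. Compound 4 takes away one of those three methoxy groups, so a partial reversal of that gain is the natural expectation, though the methoxy groups that remain keep compound 4 closer to compound 2 than compound 1 is.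

Compound 4 is therefore expected to give a modestly higher number, a step of a 1.9-fold higher number from compound 2 to compound 4 (0.28 log units; within the scatter), with an estimated 4200 nM and a likely range from 2000 nM to 9000 nM.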

Compound 4, half-maximal inhibitory concentration: 4710 nM
Estimate against measurement, compound 4: 1.1-fold (0.05 log units) below; the measured number falls inside the stated range.
By their numbers in this assay, from the lowest: compound 2; then compounds 4, 3 and 1 (each within the scatter of the next).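

In this assay, taking a single methoxy group off the 3,4,5-trimethoxyphenyl ring gives a 2.1-fold higher number from compound 2 to compound 4 (0.33 log units; beyond the scatter), so this one group accounts for a measurable difference, though the step is modest. Set against the 2-methoxyphenyl group, the 3,4-dimethoxyphenyl group gives a 2.0-fold lower number from compound 1 to compound 4 (0.30 log units; within the scatter), which lies within the scatter, so these two compounds cannot be ranked and, of the aryl groups compared here, only the 3,4,5-trimethoxyphenyl group of compound 2 stands clear of the 2-methoxyphenyl group. No measurement shown explains why removing this methoxy group changes the number.

From the compounds shown here alone, it remains open whether a different group at this place, such as an amine, a hydroxyl group or a fluorine atom, would behave like methoxy or like hydrogen. Going by these compounds, a longer ether there, such as ethoxy, is equally open.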